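Trimming Two Methyl Groups from a Thiophene Ring

This account rests on a few compounds, and the source may have more. Where it says the series, first, only, none or still open, it means among the compounds named here.

Compound 1 `Cc1cc(-c2nc3sc(C)cn3c2/C=N/NC(=N)N)c(C)s1` carries a 2,5-dimethylthiophen-3-yl group on the shared core. In a functional assay on cells (Leukemia cell, Homo sapiens) for inhibition (a lower number here means a stronger inhibitor of growth, a higher number a weaker inhibitor of growth), compound 1 gives 47900 nM, the highest of the two numbers available. Going by the values given here, the only other measured compound is compound 2 `Cc1cn2c(/C=N/Nc3ccccn3)c(-c3ccc(Cl)c([N+](=O)[O-])c3)nc2s1`, which in this assay gives 16600 nM, a lower number that lies beyond the scatter; compound 2 differs from compound 1 at several places at once, so nothing about any single change can be read from this pair. Compound 3 `Cc1cn2c(/C=N/NC(=N)N)c(-c3ccsc3)nc2s1` has not yet been measured. It differs from compound 1 by one change: thiophen-3-yl in place of 2,5-dimethylthiophen-3-yl on an aromatic carbon. Among the compounds with values here, no measured pair shows what this change does, so the expectation rests on compound 1 alone. The change is expected to produce a 1.1-fold higher number from compound 1 to compound 3 (0.06 log units; within the scatter), a step likely within the scatter. Compound 3 is therefore estimated at 55000 nM, with a range from 18000 nM to 170000 nM.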

Compound 3, concentration for 50% growth inhibition: 7760 nM
For compound 3 the middle estimate is 7.1-fold (0.85 log units) above the measured one; measured number outside the range, below it.
By their numbers in this assay, from the lowest: compound 3; then compound 2; then compound 1.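

Going by these compounds alone, replacing 2,5-dimethylthiophen-3-yl with thiophen-3-yl gives a 6.2-fold lower number from compound 1 to compound 3 (0.79 log units; beyond the scatter) in this assay and is the only single change that can be read so far. It shows that this place on the shared core responds to what the thiophene carries: here, the ring without methyl groups goes with stronger growth inhibition than the ring with them. No measurement at hand bears on why the number moves.

The compounds shown leave open whether removing both methyl groups is needed, or whether a thiophene keeping just one methyl group would give a similar number, and which of the two would matter more. They also leave open how a furan ring, or an amine or a carboxylic acid placed on the thiophene, would compare at this place.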